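This account rests on a few compounds, and the source may have more. Where it says the series, first, only, none or still open, it means among the compounds named here.

In a functional assay on HCT-116 cells (Homo sapiens) for cytotoxicity, read by MTT assay (a lower number here means a stronger inhibitor, a higher number a weaker inhibitor), compound 1 `Cc1cc(O)c(C(=O)/C=C/c2ccc(Cl)cc2)c(=O)o1` gives 87400 nM. Compound 2 `Cc1cc(O)c(C(=O)/C=C/c2ccc(-c3ccccc3)cc2)c(=O)o1` is reported as > 100000 nM, which is a limit of the assay and not a number. On these data alone, that places it at the limit of > 100000 nM in this assay, at which 1 of the 2 values shown sits, so its exact standing is unknown.

Compound 3 `Cc1cc(O)c(C(=O)/C=C/c2ccc(C#N)cc2)c(=O)o1` follows from compound 2 by cyano in place of phenyl on an aromatic carbon, with cyano in place of phenyl on an aromatic carbon. Among the measured compounds shown here, the only measured step that bears on this place is an at least 1.1-fold higher number from compound 1 to compound 2 (0.05 log units; that floor lies within the scatter), where phenyl replaced chloro on an aromatic carbon. Since that step gives no size beyond the scatter, only a modest move toward a lower number is expected in this assay, and compound 3 should remain a weak inhibitor. The expected step is an at least 1.3-fold lower number from compound 2 to compound 3 (0.12 log units; that floor lies within the scatter). For compound 3 the estimate is 75000 nM, with an expected range from 30000 nM to 100000 nM.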

Compound 3, half-maximal inhibitory concentration: 66000 nM
Beside the measured number, compound 3's estimate is 1.1-fold (0.06 log units) above it, within the range that was stated.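

In this assay, the exchange of phenyl for cyano gives an at least 1.5-fold lower number from compound 2 to compound 3 (0.18 log units; that floor lies within the scatter), so this step has only a floor, and that floor does not clear the usual scatter. The reading for compound 2 is a limit of the assay and not a number: the limit of > 100000 nM in this assay, at which 1 of the 3 values shown sits. Among the compounds shown here, the first step at this place between two true numbers is a 1.3-fold lower number from compound 1 to compound 3 (0.12 log units; within the scatter), which shows that cyano and chloro, on an aromatic carbon para to a large group, cannot be told apart in this assay.

On these data alone, the true size of the exchange of phenyl for cyano remains open, as only its floor can be read. As far as these compounds go, it also remains open whether another group at this place, such as an amine or a carboxylic acid, would move the number beyond the scatter.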